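Cytotoxicity series: naphthalenyl to chlorophenyl swap on the triazine

A few compounds are considered here, and "the series" means these few. Any claim that something is new, unique, unknown or untested is made for them only; others in the source may bear on it.

Measured compounds:
compound 1 `CC(=O)c1ccc(NC(=O)CSc2nncnc2-c2ccccc2Cl)c(Br)c1`: 34000 nM
compound 2 `CC(=O)c1ccc(NC(=O)CSc2nncnc2-c2cccc3ccccc23)c(Br)c1`: 133000 nM
compound 3 `Cc1ccc(NC(=O)CSc2nncnc2-c2cccc3ccccc23)c([N+](=O)[O-])c1`: 147000 nM

Three compounds have been run in an ADME assay on MT4 cells (Homo sapiens) for cytotoxicity, read by MTT assay; on this read-out lower numbers stand for higher toxicity in this test and higher numbers for lower toxicity in this test. Compound 1 `CC(=O)c1ccc(NC(=O)CSc2nncnc2-c2ccccc2Cl)c(Br)c1` gives 34000 nM in this assay. Compound 2 `CC(=O)c1ccc(NC(=O)CSc2nncnc2-c2cccc3ccccc23)c(Br)c1` gives 133000 nM in this assay. Compound 3 `Cc1ccc(NC(=O)CSc2nncnc2-c2cccc3ccccc23)c([N+](=O)[O-])c1` gives 147000 nM in this assay.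

Compound 2 and compound 3 share the aryl group on the core and differ only at the amide nitrogen, the change being (4-methyl-2-nitrophenyl in place of 4-acetyl-2-bromophenyl on an amide-type nitrogen). That change leaves this assay essentially unmoved: a 1.1-fold higher number from compound 2 to compound 3 (0.04 log units; within the scatter).

The change from compound 2 to compound 1 is 2-chlorophenyl in place of naphthalen-1-yl on an aromatic carbon. It gives the one clear move in the set: a 3.9-fold lower number from compound 2 to compound 1 (0.59 log units; beyond the scatter).

Compound 4 `Cc1ccc(NC(=O)CSc2nncnc2-c2ccccc2Cl)c([N+](=O)[O-])c1` is not yet measured. It relates to compound 3 as compound 1 relates to compound 2: 2-chlorophenyl in place of naphthalen-1-yl on an aromatic carbon. The place is described in identical words for both pairs, so this is the same change, made on a core that differs by 4-methyl-2-nitrophenyl in place of 4-acetyl-2-bromophenyl on an amide-type nitrogen. Within the data shown here, with only one earlier instance, the expected step rests on that one pair alone. The step from compound 3 to compound 4 in this assay is expected to be about a 3.9-fold lower number from compound 3 to compound 4 (0.59 log units; beyond the scatter), matching a 3.9-fold lower number from compound 2 to compound 1 (0.59 log units; beyond the scatter). Among the measured compounds shown here, compound 4 is therefore estimated at 38000 nM in this assay, with a range of 15000 nM to 100000 nM to allow for the single precedent.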

Compound 4, half-maximal cytotoxic concentration: 158000 nM
Estimate against measurement, compound 4: 4.2-fold (0.62 log units) below; measured number above the stated range.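

In this assay, the change to 2-chlorophenyl in place of naphthalen-1-yl does not carry over as one fixed step between the two cores: the same change on two cores in this assay, a 3.9-fold lower number (0.59 log units; beyond the scatter) from compound 2 to compound 1 and a 1.1-fold higher number (0.03 log units; within the scatter) from compound 3 to compound 4, 4.2-fold (0.62 log units) apart, beyond the scatter of two such steps. With 4-methyl-2-nitrophenyl on the amide nitrogen, the same change gives a 1.1-fold higher number from compound 3 to compound 4 (0.03 log units; within the scatter), so the clear step seen with 4-acetyl-2-bromophenyl does not recur there. Among these compounds, this shows that, in these two pairs, the outcome of the change depends on the group on the amide nitrogen, but with only two pairs it does not show which part of that group matters, or how the change would behave on any third core.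

The compounds shown leave open whether the acetyl or the bromine of 4-acetyl-2-bromophenyl goes with the step seen on that core, and how the change behaves with other amide substituents, such as a phenyl ring carrying an amine or a carboxylic acid. They also leave open whether other groups in place of naphthalen-1-yl, such as 2-fluorophenyl or unsubstituted phenyl, follow the pattern of either pair.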